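Aryl swap on the ring nitrogen of an inactive pair

A few compounds are considered here, and "the series" means these few. Any claim that something is new, unique, unknown or untested is made for them only; others in the source may bear on it.

Compound 1 `Cc1cc(C)cc(-n2nncc2CN2C(=O)C3(C(C#N)=C(N)Oc4c3c3nc5ccccc5nc3c3ccccc43)c3ccccc32)c1` and compound 2 `Cc1ccc(-n2nncc2CN2C(=O)C3(C(C#N)=C(N)Oc4c3c3nc5ccccc5nc3c3ccccc43)c3ccccc32)c(C)c1` share one core and differ only in the aryl group on an aromatic nitrogen. In a functional assay on HepG2 cells (Homo sapiens) for antiproliferative activity, read by MTT assay, with a stated time of 48 h (a lower number here means a stronger inhibitor, a higher number a weaker inhibitor), compound 1 gives only a limit, > 50000 nM. In this assay compound 2 likewise gives only a limit, > 50000 nM. For the measured compounds named here, the single measured step, a step that the two limits leave unreadable from compound 1 to compound 2, cannot be sized because both values sit at the limit of > 50000 nM in this assay, at which 2 of the 2 values shown sit. Compound 2 therefore stands at the assay limit, with no number to place it against any other compound.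

Compound 3 `N#CC1=C(N)Oc2c(c3nc4ccccc4nc3c3ccccc23)C12C(=O)N(Cc1cnnn1-c1cc(Cl)ccc1Cl)c1ccccc12` carries 2,5-dichlorophenyl in place of 2,4-dimethylphenyl on an aromatic nitrogen. Going by the values given here, the one measured step touches the same position but is unreadable, so no measured size is available for this change. With both neighbours at the limit, compound 3 is expected to remain there as well, at an estimated 70000 nM, within 20000 nM to 250000 nM, and most likely reported again only as a limit. The step this estimate means, a step that the limit leaves unreadable from compound 2 to compound 3, is expected to be none beyond the scatter.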

Compound 3, half-maximal inhibitory concentration: > 50000 nM
Compound 3: no number, only a limit; the forecaster's own chance of this, stated with the estimate: 85%; the middle value lies beyond the limit too.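

For the compounds shown here, compound 3 gives only a limit in this assay, so no step among compound 1, compound 2 and compound 3 can be read: the limit of > 50000 nM in this assay, at which 3 of the 3 values shown sit.

The compounds shown leave open whether any aryl group at this aromatic nitrogen on the shared core gives a measurable value in this assay rather than a limit.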